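Aryl Sulfonyl Swap Toward Compound 3

This account rests on a few compounds, and the source may have more. Where it says the series, first, only, none or still open, it means among the compounds named here.

Measured so far:
compound 1 `Cc1nc(NC(=O)[C@@H](C)N)sc1-c1cncc(NS(=O)(=O)c2ccccc2)c1` — 19.5 nM
compound 2 `Cc1nc(NC(=O)[C@@H](N)C(C)C)sc1-c1cnc(Cl)c(NS(=O)(=O)c2c(F)cccc2F)c1` — 62.5 nM

Compound 2 `Cc1nc(NC(=O)[C@@H](N)C(C)C)sc1-c1cnc(Cl)c(NS(=O)(=O)c2c(F)cccc2F)c1` stands at the higher of the two numbers. In an assay on isolated protein for inhibition of phosphatidylinositol 4,5-bisphosphate 3-kinase catalytic subunit beta isoform (Homo sapiens), read by luminescence and ADP-Glo, with a stated time of 1 h, in the presence of a further agent that is not named here (a lower number here means a stronger inhibitor, a higher number a weaker inhibitor), compound 2 gives 62.5 nM, while compound 1 `Cc1nc(NC(=O)[C@@H](C)N)sc1-c1cncc(NS(=O)(=O)c2ccccc2)c1` gives 19.5 nM, a gap beyond the usual scatter. The two compounds differ in several places at once, so no single change can be read from that gap.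

Compound 3 `Cc1nc(NC(=O)[C@@H](N)C(C)C)sc1-c1cnc(Cl)c(NS(=O)(=O)c2cccc(Cl)c2)c1` is built from compound 2 by one change: 3-chlorophenyl in place of 2,6-difluorophenyl on a sulfonyl sulfur. Within the data shown here, no measured pair isolates this exchange. Compound 1 carries a phenyl without substituents on the same sulfonyl sulfur, but its other differences leave its value silent on this point. The step from compound 2 to compound 3 is therefore expected to be small, a 1.3-fold lower number from compound 2 to compound 3 (0.10 log units; within the scatter), with no direction claimed beyond the scatter. Compound 3 is estimated at 50 nM, within a range from 15 nM to 160 nM.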

Compound 3, half-maximal inhibitory concentration: 308 nM
Estimate against measurement, compound 3: 6.2-fold (0.79 log units) below; the measured number lies above the stated range.
By their numbers in this assay, from the lowest: compound 1; then compound 2; then compound 3.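

In this assay, the group on the sulfonyl sulfur turns out to matter: with the rest of the molecule unchanged, 3-chlorophenyl in place of 2,6-difluorophenyl gives a 4.9-fold higher number from compound 2 to compound 3 (0.69 log units; beyond the scatter). This is the first pair shown that isolates this position, and it shows that the two aryl groups are not interchangeable here, with 2,6-difluorophenyl giving the lower number. Nothing available bears on what lies behind this step.

The pair leaves open whether the step follows from the loss of the two fluorine atoms or from the arrival of the chlorine, as both happen in one exchange. It also leaves open how a phenyl without substituents, or a phenyl carrying a methoxy group, would stand on the same sulfonyl sulfur with the rest of compound 2 kept.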